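The compounds below may be only part of what the source reports. "The series", "measured", "known", "first", "only" and "open" are said of these compounds alone.

Three compounds share one core and differ only in the group carried on an amide-type nitrogen. Compound 1 `O=C(Nc1ccccn1)c1c(O)c2cccnc2n(-c2ccccc2)c1=O` bears pyridin-2-yl there, compound 2 `O=C(NCc1ccccc1)c1c(O)c2cccnc2n(-c2ccccc2)c1=O` benzyl, and compound 3 `CN(C)CCNC(=O)c1c(O)c2cccnc2n(-c2ccccc2)c1=O` 2-(dimethylamino)ethyl. In a functional assay on the whole organism for inhibition, with Rattus norvegicus as the target, read by paw edema, at a dose of 100 mg/kg by the oral route (a higher number here means more inhibition at the dose given (going by the name of the read-out), a lower number less inhibition), compound 1 gives -13.5%, compound 2 gives 1.6%, and compound 3 gives 22.6%. Compound 3 thus stands highest of the three, and each step toward it lies beyond the scatter: a number 15.1 percentage points higher from compound 1 to compound 2 (beyond the scatter), a number 21 percentage points higher from compound 2 to compound 3 (beyond the scatter) and a number 36.1 percentage points higher from compound 1 to compound 3 (beyond the scatter).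

Compound 4 `O=C(Nc1ccccc1)c1c(O)c2cccnc2n(-c2ccccc2)c1=O` is the next step: phenyl in place of 2-(dimethylamino)ethyl on an amide-type nitrogen. Phenyl is a ring placed directly on the amide-type nitrogen, as pyridin-2-yl is in compound 1, and it is the benzyl of compound 2 without its chain carbon. Both ring-bearing compounds sit well below compound 3 in this assay, so a drop back toward their level is expected, and the step to compound 4 is estimated as a number 26.6 percentage points lower from compound 3 to compound 4 (beyond the scatter). For compound 4 the expected value in this assay is -4%, with a range from -24% to 16%.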

Compound 4, a percentage reported as inhibition, in the whole organism at one dose (the size of the read-out at that dose, not a potency): 4.6%
Compound 4: middle estimate off by 8.6 percentage points, on the low side, and the stated range covers the measured number.
By their numbers in this assay, from the lowest: compound 1; then compounds 2 and 4 (each within the scatter of the next); then compound 3.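

In this assay the change to phenyl gives a number 18 percentage points lower from compound 3 to compound 4 (beyond the scatter) and so leaves the 2-(dimethylamino)ethyl group of compound 3 as the only one of the four that stands clear of all the others. Phenyl and benzyl cannot be told apart here, at a number 3 percentage points higher from compound 2 to compound 4 (within the scatter) and so the chain carbon of benzyl shows no effect on this read-out. Two rings placed directly on the amide-type nitrogen do differ, with a number 18.1 percentage points higher from compound 1 to compound 4 (beyond the scatter) showing that the kind of ring counts, not only whether a ring is there.

Going by these compounds, whether the higher number of compound 3 belongs to its amine or to the chain carrying it stays open, and a plain butyl group or a longer chain ending in the same amine would bear on that. Nothing measured here explains these differences.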